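Propylamino to cyclohexylamino among weakly cytotoxic compounds

A few compounds are considered here, and "the series" means these few. Any claim that something is new, unique, unknown or untested is made for them only; others in the source may bear on it.

In an ADME assay on BCBL1 cells (Homo sapiens) for cytotoxicity, with a stated time of 7 days (a higher number here means that more compound is tolerated, a lower number that less compound is tolerated), compound 3 `CCCNc1nc(N)nc2c1ncn2/C=C1/CC1(CO)CO` gives > 20000 nM, which is a limit and not a number. Compound 1 `C=CCOc1nc(N)nc2c1ncn2/C=C1/CC1(CO)CO` likewise gives only a limit, > 20000 nM. Among the measured compounds shown here, compound 2 `Nc1nc(NC2CC2)c2ncn(/C=C3/CC3(CO)CO)c2n1` is the only one with a real number, 71500 nM. Compound 4 `Nc1nc(NC2CCCCC2)c2ncn(/C=C3/CC3(CO)CO)c2n1` has cyclohexyl in place of propyl on a nitrogen on an aromatic ring. The closest measured change is a step that the limit leaves unreadable from compound 2 to compound 3, and a step that the limit leaves unreadable from compound 1 to compound 2 and a step that the two limits leave unreadable from compound 1 to compound 3 say no more, since most results sit at the limit of > 20000 nM in this assay, at which 2 of the 3 values shown sit. No measured size therefore carries over, and no direction is expected in this assay. The expected change is a step that the limit leaves unreadable from compound 3 to compound 4, though this is only loosely estimated. For compound 4 the estimate is 45000 nM, with an expected range from 12000 nM to 100000 nM.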

Compound 4, half-maximal cytotoxic concentration: > 20000 nM
Compound 4: no number, only a limit; the forecaster's own chance of this, stated with the estimate: 55%; the middle value does not contradict the limit.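

Compound 4 gives only a limit, so no step from it to compound 1, compound 2 or compound 3 can be read, and the same holds for compound 1 and compound 3, because the results pile up at one value: the limit of > 20000 nM in this assay, at which 3 of the 4 values shown sit.

In this assay, the compounds shown leave open whether cyclohexyl in place of propyl changes how much compound is tolerated.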